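This account rests on a few compounds, and the source may have more. Where it says the series, first, only, none or still open, it means among the compounds named here.

Measured so far in an assay for inhibition of Aromatase (Homo sapiens); on this read-out lower numbers stand for stronger inhibition and higher numbers for weaker inhibition: compound 1 `COc1ccc2c(=O)c(-c3ccccc3)c(-n3ccnc3)oc2c1` gives 770 nM; compound 2 `COc1ccc2c(=O)c(-c3ccccc3)c(-n3cncn3)oc2c1` gives 18000 nM.

Compound 2 stands highest of the two numbers, with compound 1 the nearer one. Among the compounds with values here, the single measured step, a 23-fold higher number from compound 1 to compound 2 (1.37 log units; beyond the scatter), is large and shows that the five-membered ring on this carbon decides much. Compound 3 `COc1ccc2c(=O)c(-c3ccccc3)c(Sc3ncc[nH]3)oc2c1` carries the change ((1H-imidazol-2-yl)sulfanyl in place of 1H-1,2,4-triazol-1-yl on an aromatic carbon). Within the data shown here, no measured step covers a sulfanyl-linked ring, so only the weight of the azole exchange bears on it. Expected for compound 3: a 6.0-fold lower number from compound 2 to compound 3 (0.78 log units; beyond the scatter), a return toward the imidazole level of compound 1 770 nM being plausible. Estimate for compound 3: 3000 nM (range 500 nM to 20000 nM).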

Compound 3, half-maximal inhibitory concentration: > 50000 nM
Compound 3: no number, only a limit; the forecaster's own chance of this, stated with the estimate: 10%; middle value at least 16-fold (1.22 log units) from the limit.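

In this assay compound 3 gives no number, only a limit: the limit of > 50000 nM in this assay, at which 1 of the 3 values shown sits. Read against the azoles attached directly through nitrogen, the limit gives an at least 2.7-fold higher number from compound 2 to compound 3 (0.44 log units; beyond the scatter) and an at least 64-fold higher number from compound 1 to compound 3 (1.81 log units; beyond the scatter). This position therefore does not simply reward an imidazole ring: the (1H-imidazol-2-yl)sulfanyl group sits beyond both the 1H-imidazol-1-yl and the 1H-1,2,4-triazol-1-yl compounds.

Open, as far as these compounds go, is whether the loss follows the sulfur link or the attachment through a ring carbon of the imidazole. A methylene link to the same ring, or a simple amine on this carbon, would help separate the two.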